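The source may hold more compounds than are shown below. What is called first, only, known or untested is meant among the compounds shown, and "the series" means these compounds.

Measured compounds:
- Compound 1, `O=C1O[C@H]([C@@H](O)Cn2cc(-c3ccc(Br)cc3)nn2)C(OCc2ccccc2)=C1OCc1ccccc1`, in a functional assay on A549 cells (Homo sapiens) for antiproliferative activity, read by MTT assay, with a stated time of 72 h (on this read-out higher numbers stand for weaker inhibition and lower numbers for stronger inhibition), compound 1 gives 750 nM.
- Compound 2, `O=C1O[C@H]([C@@H](O)Cn2cc(CNS(=O)(=O)c3ccc(F)cc3)nn2)C(OCc2ccccc2)=C1OCc1ccccc1`, compound 2 gives 22500 nM.
- Compound 3, `O=C1O[C@H]([C@@H](O)Cn2cc(-c3cc(F)cc(F)c3)nn2)C(OCc2ccccc2)=C1OCc1ccccc1`, compound 3 gives 41200 nM.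

Compound 3 stands highest of the three numbers: compound 2 is its nearest neighbour, and the step of a 1.8-fold higher number from compound 2 to compound 3 (0.26 log units; within the scatter) lies within the scatter, whereas the step of a 55-fold higher number from compound 1 to compound 3 (1.74 log units; beyond the scatter) is large and beyond it. Compound 4, `Cc1ccc(S(=O)(=O)NCc2cn(C[C@H](O)[C@H]3OC(=O)C(OCc4ccccc4)=C3OCc3ccccc3)nn2)cc1`, is obtained from compound 3 by the change ((((4-methylphenyl)sulfonyl)amino)methyl in place of 3,5-difluorophenyl on an aromatic carbon). Among the compounds with values here, two measured steps bear on this. The step of a 30-fold higher number from compound 1 to compound 2 (1.48 log units; beyond the scatter) shows that a sulfonamidomethyl group of this kind gives a number far above that of compound 1, and the step of a 1.8-fold higher number from compound 2 to compound 3 (0.26 log units; within the scatter) shows that such a group and the 3,5-difluorophenyl group end up within the scatter of each other. Within the data shown here, compound 4 carries a group that differs from the one in compound 2 only in the substituent on its phenyl ring, so compound 4 is expected to land near compound 2, with the step of a 1.9-fold lower number from compound 3 to compound 4 (0.27 log units; within the scatter) expected to stay within the scatter. Compound 4 is therefore estimated at 22000 nM, in the range 8000 nM to 60000 nM.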

Compound 4, half-maximal inhibitory concentration: 16800 nM
Estimate against measurement, compound 4: 1.3-fold (0.12 log units) above; the range from low to high includes it.
By their numbers in this assay, from the lowest: compound 1; then compounds 4, 2 and 3 (each within the scatter of the next, the first and the last beyond it).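

In this assay, methyl in place of fluoro on an aromatic carbon gives a 1.3-fold lower number from compound 2 to compound 4 (0.13 log units; within the scatter), so the two sulfonamidomethyl groups cannot be told apart at this position. Within the data shown here, the (((4-methylphenyl)sulfonyl)amino)methyl group also gives a 22-fold higher number from compound 1 to compound 4 (1.35 log units; beyond the scatter), which shows that the large gap to the 4-bromophenyl group is not confined to the single sulfonamidomethyl group seen before. Against the 3,5-difluorophenyl group it gives a 2.5-fold lower number from compound 3 to compound 4 (0.39 log units; beyond the scatter), a modest step beyond the scatter, even though the 3,5-difluorophenyl and (((4-fluorophenyl)sulfonyl)amino)methyl groups lie within the scatter of each other.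

Nothing shown here explains any of these steps. As far as these compounds go, it remains open how a 4-chlorophenyl group, an unsubstituted phenyl group, or a sulfonamidomethyl group with an amine or a carboxylic acid on its phenyl ring would stand on this aromatic carbon.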